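The source may report more compounds than this note shows. Statements on the series, on what has been measured and on what is new or still open speak of the compounds shown alone.

Compound 1 `O=c1[nH]cnc2c1c(-c1cccs1)cn2[C@@H]1O[C@H](CO)[C@@H](O)[C@H]1O` carries a thiophen-2-yl group. In a functional assay on HCT-116 cells (Homo sapiens), read by MTT assay, with a stated time of 72 h (a higher number here means a weaker inhibitor, a lower number a stronger inhibitor), compound 1 gives > 20000 nM, a limit of the assay rather than a number, so compound 1 stands at the edge of what could be measured (the limit of > 20000 nM in this assay, at which 1 of the 2 values shown sits). Compound 2 `Nc1nc2c(c(-c3cccs3)cn2[C@@H]2O[C@H](CO)[C@@H](O)[C@H]2O)c(=O)[nH]1` gives 19800 nM in this assay. Among the measured compounds shown here, the single measured step, a number no higher from compound 1 to compound 2 (the limit leaves the size open), concerns amino in place of hydrogen and does not touch the ring change. Compound 3 `O=c1[nH]cnc2c1c(-c1cc3ccccc3o1)cn2[C@@H]1O[C@H](CO)[C@@H](O)[C@H]1O` differs from compound 1 by 1-benzofuran-2-yl in place of thiophen-2-yl on an aromatic carbon. For the measured compounds named here, no measured step bears on this change, so nothing beyond the scatter is expected from an at least 1.3-fold lower number from compound 1 to compound 3 (0.12 log units; that floor lies within the scatter). Compound 3 is therefore estimated at 15000 nM, between 3000 nM and 60000 nM in this assay.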

Compound 3, half-maximal inhibitory concentration: > 20000 nM
Compound 3 was reported as a limit (the forecaster's own chance of this, stated with the estimate: 55%); middle value at least 1.3-fold (0.12 log units) away from the limit.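

Compound 3, like compound 1, stands at a limit rather than a number in this assay, so no step can be read between the two: the limit of > 20000 nM in this assay, at which 2 of the 3 values shown sit. As far as these compounds go, whether 1-benzofuran-2-yl in place of thiophen-2-yl changes the number at all, and in which direction, stays open.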